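Swapping the aryl group on a thiosemicarbazone

A few compounds are considered here, and "the series" means these few. Any claim that something is new, unique, unknown or untested is made for them only; others in the source may bear on it.

Measured in a functional assay on HT-29 cells (Homo sapiens) for cytotoxicity, read by sulforhodamine B assay (a lower number here means that less compound is tolerated, a higher number that more compound is tolerated), as follows:

- compound 1 `CC1=CC[C@@H]([C@@](C)(O)CCCC(C)(C)NC=S)CC1` gives 90300 nM
- compound 2 `CC1=CC[C@@H]([C@@](C)(O)CCCC(C)(C)NC(=S)NN)CC1` gives > 100000 nM
- compound 3 `CC1=CC[C@@H]([C@@](C)(O)CCCC(C)(C)NC(=S)N/N=C\c2ccc(O)cc2)CC1` gives 58500 nM

The entry for compound 2 is a limit of the assay, not a number. Compound 3 (58500 nM) lies within the scatter of compound 1 (90300 nM). Compound 4 `CC1=CC[C@@H]([C@@](C)(O)CCCC(C)(C)NC(=S)N/N=C\c2cccc([N+](=O)[O-])c2)CC1` has 3-nitrophenyl in place of 4-hydroxyphenyl on a carbon with a double bond to nitrogen. Among the compounds with values here, no measured step makes this exact swap. The nearest steps, an at least 1.1-fold higher number from compound 1 to compound 2 (0.04 log units; that floor lies within the scatter) and an at least 1.7-fold lower number from compound 2 to compound 3 (0.23 log units; that floor lies within the scatter), are both only floors set by that limit, and neither floor lies beyond the scatter. No step beyond the scatter is therefore expected in this assay here. The expected step is a 1.2-fold lower number from compound 3 to compound 4 (0.09 log units; within the scatter) in this estimate. Compound 4 is estimated at 48000 nM with 20000 nM to 100000 nM as its expected range.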

Compound 4, concentration lethal to 50% of the cells: > 100000 nM
Compound 4: a limit, no number (the forecaster's own chance of this, stated with the estimate: 15%); middle value at least 2.0-fold (0.31 log units) from the limit.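

In this assay compound 4 gives > 100000 nM, which is a limit of the assay and not a number. Putting 3-nitrophenyl in place of 4-hydroxyphenyl on the carbon with a double bond to nitrogen gives an at least 1.7-fold higher number from compound 3 to compound 4 (0.23 log units; that floor lies within the scatter), so this aryl swap shows no step beyond the scatter, and its full size cannot be read: the limit of > 100000 nM in this assay, at which 2 of the 4 values shown sit.

The swap changes both the ring's substituent and its ring position, and the compounds shown do not separate the two. Also open, from the compounds shown here alone, is whether 4-nitrophenyl, 3-hydroxyphenyl or 4-aminophenyl at this carbon would give a clearly lower number.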